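Phenoxy in Place of Phenyl: Expected Shift in Inhibition

The source may report more compounds than this note shows. Statements on the series, on what has been measured and on what is new or still open speak of the compounds shown alone.

Among the measured compounds shown here, in an assay on RBL-1 cells for inhibition of Polyunsaturated fatty acid 5-lipoxygenase (Rattus norvegicus) (on this read-out lower numbers stand for stronger inhibition and higher numbers for weaker inhibition), compound 1 `O=C(/C=C\N(O)Cc1ccc(OCc2ccccc2)cc1)C1CC1` gives 2600 nM, while compound 2 `O=C(/C=C\N(O)Cc1ccc(-c2ccccc2)cc1)C1CC1` gives 1200 nM, the lowest of the two numbers so far. For the measured compounds named here, the single step joining them is a 2.2-fold lower number from compound 1 to compound 2 (0.34 log units; beyond the scatter). Compound 3 `O=C(/C=C\N(O)Cc1ccc(Oc2ccccc2)cc1)C1CC1` carries phenoxy in place of phenyl on an aromatic carbon; in make-up its phenoxy stands between the benzyloxy of compound 1 and the phenyl of compound 2. Going by the values given here, only that one step bears on the change, so compound 3 is expected to show a modest move back toward compound 1, a 1.4-fold higher number from compound 2 to compound 3 (0.15 log units; within the scatter). Compound 3 is therefore estimated at 1700 nM, within 800 nM to 3600 nM.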

Compound 3, half-maximal inhibitory concentration: 1400 nM
Beside the measured number, compound 3's estimate is 1.2-fold (0.08 log units) above it; low and high end bracket the measured number.
By their numbers in this assay, from the lowest: compounds 2, 3 and 1 (each within the scatter of the next, the first and the last beyond it).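

In this assay, phenoxy and phenyl on this aromatic carbon cannot be told apart (a 1.2-fold higher number from compound 2 to compound 3 (0.07 log units; within the scatter)). Phenyl in place of benzyl on the oxygen also stays within the scatter (a 1.9-fold lower number from compound 1 to compound 3 (0.27 log units; within the scatter)), so compound 3 lies within the scatter of both compound 1 and compound 2, although those two lie beyond it from each other. No measurement at hand offers a reason for these numbers. The compounds shown leave open whether an amine, a carboxylic acid or a longer chain at this place would take the number beyond the scatter of compound 2.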